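A few compounds are considered here, and "the series" means these few. Any claim that something is new, unique, unknown or untested is made for them only; others in the source may bear on it.

Of the compounds shown here, three that share one core have been measured in a functional assay on HCT-116 cells (Homo sapiens) for antiproliferative activity, read by MTT assay, with a stated time of 72 h; on this read-out higher numbers stand for weaker inhibition and lower numbers for stronger inhibition. Compound 1 `CN(C(=O)c1ccc(Br)cc1)c1ccc2[nH]c(-c3n[nH]c4ccccc34)cc2n1` gives 6110 nM. Compound 2 `CN(C(=O)c1ccco1)c1ccc2[nH]c(-c3n[nH]c4ccccc34)cc2n1` gives 30000 nM in this assay. Compound 3 `CN(c1ccc2[nH]c(-c3n[nH]c4ccccc34)cc2n1)S(=O)(=O)c1ccccc1` gives 6740 nM in this assay. Among these three numbers compound 3 stands second highest: the step of a 1.1-fold higher number from compound 1 to compound 3 (0.04 log units; within the scatter) lies within the scatter, so those two compounds cannot be told apart, while a 4.5-fold lower number from compound 2 to compound 3 (0.65 log units; beyond the scatter) is a modest move beyond the scatter.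

Compound 4 `COc1ccc(S(=O)(=O)N(C)c2ccc3[nH]c(-c4n[nH]c5ccccc45)cc3n2)c(OC)c1` differs from compound 3 in one place: 2,4-dimethoxyphenyl in place of phenyl on a sulfonyl sulfur. Among the measured compounds shown here, no measured step alters the ring attached to the sulfonyl sulfur, so none bears directly on this change. The nearest parallel is a 4.9-fold higher number from compound 1 to compound 2 (0.69 log units; beyond the scatter), where the ring attached to a carbonyl carbon was exchanged for a different one, a modest step; the exchange of the whole attachment in a 1.1-fold higher number from compound 1 to compound 3 (0.04 log units; within the scatter) moved nothing beyond the scatter. On this footing the expected step of a 1.2-fold lower number from compound 3 to compound 4 (0.09 log units; within the scatter) is small, most likely within the scatter and in no firm direction. Compound 4 is therefore estimated at 5500 nM in this assay, with a range from 2000 nM to 16000 nM.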

Compound 4, half-maximal inhibitory concentration: 21800 nM
Compound 4: the middle estimate sits 4.0-fold (0.60 log units) below what was measured, and the stated range ends below it.
By their numbers in this assay, from the lowest: compounds 1 and 3 (each within the scatter of the next); then compounds 4 and 2 (each within the scatter of the next).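

In this assay, the ring on the sulfonyl sulfur proves not to be a silent place: a 3.2-fold higher number from compound 3 to compound 4 (0.51 log units; beyond the scatter) is a modest move beyond the scatter, towards weaker inhibition. Among the compounds shown here, until now, the only ring exchange that moved the number beyond the scatter was on a carbonyl carbon, so this result adds a change on the sulfonyl side that also registers. Here the six-membered aromatic ring of carbon only stays in place and the difference lies in the two methoxy groups that 2,4-dimethoxyphenyl carries, though no measurement available here explains why the number rises.

Both methoxy groups enter together, so the compounds shown cannot tell whether one of them alone accounts for the step or whether both are needed, and a phenyl ring carrying a single methoxy group would separate these cases. From the compounds shown here alone, it also remains open whether other groups on this ring, such as a methyl, a chlorine or an amine, would leave the number where compound 3 has it or shift it in either direction.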